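The source may report more compounds than this note shows. Statements on the series, on what has been measured and on what is new or still open speak of the compounds shown alone.

Measured so far:
- compound 1, `O=S(=O)(c1cc(F)cc(F)c1)c1cnc2c(F)cccc2c1-c1ccccc1F`, which in an ADME assay on microsomes from liver (Homo sapiens) for metabolic stability, tested at 2.5 uM (a higher number here means faster removal of the compound, a lower number slower removal), gives 0.09 mL/min
- compound 2, `O=S(=O)(c1cc(Cl)cc(Cl)c1)c1cnc2c(F)cccc2c1-c1ccccc1F`, which in this assay gives 0.44 mL/min

Compound 2 has the higher of these two numbers. Among the measured compounds shown here, the only measured step, a 4.9-fold higher number from compound 1 to compound 2 (0.69 log units; beyond the scatter), separates it from compound 1 and is beyond the scatter, so exchanging two fluorines for two chlorines on the sulfonyl-bound ring went with faster removal.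

Compound 3, `O=S(=O)(c1cccc(F)c1)c1cnc2c(F)cccc2c1-c1ccccc1F`, has not yet been measured. It differs from compound 2 in one place: 3-fluorophenyl in place of 3,5-dichlorophenyl on a sulfonyl sulfur. For the measured compounds named here, this change reverses the direction of the only measured step, since the remaining halogen is again fluorine, as in compound 1, and it also drops one halogen altogether, a change for which no measured step exists. The step from compound 1 to compound 2 is the one that bears on it, and it suggests a downward move of similar size, back towards the number of compound 1, with added uncertainty from the missing halogen.

Compound 3 is therefore estimated to give 0.12 mL/min, within a range from 0.04 mL/min to 0.35 mL/min. That estimate corresponds to an expected step of a 3.7-fold lower number from compound 2 to compound 3 (0.56 log units; beyond the scatter).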

Compound 3, intrinsic clearance in a liver preparation (reported as CLH), per the amount of preparation that the assay uses: 0.21 mL/min
Compound 3: middle estimate off by 1.8-fold (0.24 log units), on the low side, within the range that was stated.
By their numbers in this assay, from the lowest: compound 1; then compound 3; then compound 2.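

In this assay, putting hydrogen in place of one fluoro on the ring bound to the sulfonyl sulfur gives a 2.3-fold higher number from compound 1 to compound 3 (0.37 log units; beyond the scatter), so removing a single halogen from this ring changes the number even when no chlorine is involved. Moving to 3-fluorophenyl in place of 3,5-dichlorophenyl gives a 2.1-fold lower number from compound 2 to compound 3 (0.32 log units; beyond the scatter), which leaves the ring with one fluorine in the middle of the three: having fewer halogens does not simply lower the number, since the ring with two fluorines has the lowest number and the ring with one fluorine a higher one, while the ring with two chlorines has the highest. No accompanying measurement explains why the number moves with these changes. A 3-chlorophenyl group would compare one chlorine directly with one fluorine and with two chlorines, and an unsubstituted phenyl ring would show where a ring with no halogen falls in this order. As far as these compounds go, it also remains open how groups of a different kind on this ring, such as a methoxy group, an amine or a carboxylic acid, would compare with the halogens.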